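The compounds below may be only part of what the source reports. "The series", "measured", "known", "first", "only" and "open" are said of these compounds alone.

Compound 1 `Cc1nn(-c2ncnc3nc[nH]c23)c2c1C(OC1CCCC1)CC(=O)N2`, compound 2 `Cc1nn(-c2ncnc3nc[nH]c23)c2c1C(OCCc1ccccc1)CC(=O)N2` and compound 3 `Cc1nn(-c2ncnc3nc[nH]c23)c2c1C(c1ccc(F)cc1Cl)CC(=O)N2` share one core and differ only in the group on a saturated ring carbon. In a functional assay on HEK293 cells for agonist activity at G-protein coupled receptor 39 (Homo sapiens), read by scintillation proximity assay and inositol phosphate accumulation, with a stated time of 75 min, in the presence of a further agent that is not named here (on this read-out higher numbers stand for an effect only at larger amounts of compound and lower numbers for an effect already at smaller amounts), compound 1 gives 2 nM, compound 2 gives 3 nM and compound 3 gives 9 nM. The step of a 1.5-fold higher number from compound 1 to compound 2 (0.18 log units; within the scatter) shows that the two ethers sit together, whereas a 4.5-fold higher number from compound 1 to compound 3 (0.65 log units; beyond the scatter) and a 3.0-fold higher number from compound 2 to compound 3 (0.48 log units; beyond the scatter) place compound 3 at the highest number of the three, beyond the scatter from both. Compound 4 `Cc1nn(-c2ncnc3nc[nH]c23)c2c1C(C(=O)N(C)c1nccs1)CC(=O)N2` is now to be measured in this assay; it differs from compound 3 by methyl(1,3-thiazol-2-yl)carbamoyl in place of 2-chloro-4-fluorophenyl on a saturated ring carbon. The two steps that bear on this position, a 4.5-fold higher number from compound 1 to compound 3 (0.65 log units; beyond the scatter) and a 3.0-fold higher number from compound 2 to compound 3 (0.48 log units; beyond the scatter), are modest and show that a change of the group here shifts the number only modestly. Within the data shown here, no measured compound carries a carbamoyl at this position, so the direction is open; the amide is expected to move the number somewhat further, by an estimated 3.3-fold higher number from compound 3 to compound 4 (0.52 log units; beyond the scatter). Compound 4 is therefore expected to give about 30 nM, within a range from 5 nM to 200 nM.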

Compound 4, half-maximal effective concentration: 18 nM
The estimate for compound 4 lay 1.7-fold (0.22 log units) above the measured number; the measured number falls inside the stated range.
By their numbers in this assay, from the lowest: compounds 1 and 2 (each within the scatter of the next); then compounds 3 and 4 (each within the scatter of the next).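

Compound 4 shows that a methyl(1,3-thiazol-2-yl)carbamoyl on the saturated ring carbon, with its five-membered aromatic ring and a double bond outside that ring, gives a number that stands with that of the 2-chloro-4-fluorophenyl: the step is a 2.0-fold higher number from compound 3 to compound 4 (0.30 log units; within the scatter) and so does not separate the two groups. Against the ethers, the results are a 6.0-fold higher number from compound 2 to compound 4 (0.78 log units; beyond the scatter) and a 9.0-fold higher number from compound 1 to compound 4 (0.95 log units; beyond the scatter), so among these four compounds the two ethers form one set and the two compounds without an ether oxygen at this carbon form another, with no compound going against this. Nothing given here bears on why the compounds divide in this way.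

On these data alone, it remains open whether an amide with a hydrogen in place of the methyl would stay with compound 4. As far as these compounds go, it is equally open where an amine or a carboxylic acid on this carbon would fall.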